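This account rests on a few compounds, and the source may have more. Where it says the series, first, only, none or still open, it means among the compounds named here.

Values in an ADME assay on HepG2 cells (Homo sapiens) for cytotoxicity, with a stated time of 72 h; a higher number here means that more compound is needed for the effect, a lower number that less compound is needed:
Compound 1 `Cc1cc(NC(=O)Nc2ccccc2N)c2ccccc2n1`: > 25000 nM, a limit
Compound 2 `COc1ccccc1NC(=O)Nc1cc(C)nc2ccccc12`: > 25000 nM, a limit

Compound 2 stands at > 25000 nM, which is a limit and not a number. Compound 3 `Cc1cc(NC(=O)Nc2ccccc2C(F)(F)F)c2ccccc2n1` carries trifluoromethyl in place of methoxy on an aromatic carbon. Among the measured compounds shown here, the only measured step, a step that the two limits leave unreadable from compound 1 to compound 2, changes the group on the same aromatic carbon, but it gives no size to carry over. The evidence consists of the limit of > 25000 nM in this assay, at which 2 of the 2 values shown sit. No step beyond the scatter is therefore expected in this assay, in either direction. Compound 3 is expected at 25000 nM, with an estimated range of 10000 nM to 50000 nM. The expected change is a number no higher from compound 2 to compound 3 (the limit leaves the size open).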

Compound 3, half-maximal effective concentration: > 25000 nM
Compound 3: a limit, no number (the forecaster's own chance of this, stated with the estimate: 80%); the middle value lies on the limit itself.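

In this assay, among the compounds shown here, compound 3 gives > 25000 nM, a limit and not a number, so no step from it to compound 1 or compound 2 can be read. The compounds shown leave open whether amino, methoxy and trifluoromethyl differ at all in this assay.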